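Isoxazole for Pyrimidine on the Sulfonamide of Compound 2

A few compounds are considered here, and "the series" means these few. Any claim that something is new, unique, unknown or untested is made for them only; others in the source may bear on it.

Measured compounds:
compound 1 `Cc1cc(NS(=O)(=O)c2ccc(NCc3coc4ccccc4c3=O)cc2)no1`: 34500 nM
compound 2 `O=C1/C(=C/c2coc3ccccc3c2=O)N=C(c2ccc(Cl)cc2)N1c1ccc(S(=O)(=O)Nc2ncccn2)cc1`: > 100000 nM
compound 3 `Cc1cc(C)nc(NS(=O)(=O)c2ccc(NCc3coc4ccccc4c3=O)cc2)n1`: 93600 nM

In a functional assay on MCF7 cells (Homo sapiens) for cytotoxicity, read by sulforhodamine B assay, with a stated time of 72 h (on this read-out higher numbers stand for weaker inhibition and lower numbers for stronger inhibition), compound 2 gives only a limit, > 100000 nM, so its standing among the three is known only as the weakest end of the measurements; (the limit of > 100000 nM in this assay, at which 1 of the 3 values shown sits). Compound 4 `Cc1cc(NS(=O)(=O)c2ccc(N3C(=O)/C(=C/c4coc5ccccc5c4=O)N=C3c3ccc(Cl)cc3)cc2)no1` differs from compound 2 in one place: 5-methyl-1,2-oxazol-3-yl in place of pyrimidin-2-yl on a sulfonamide nitrogen. Among the measured compounds shown here, the only measured step that bears on this exchange runs between compound 1 and compound 3, where a 2.7-fold higher number from compound 1 to compound 3 (0.43 log units; beyond the scatter). Read in the opposite direction, that step speaks for the isoxazole over a pyrimidine, though the pyrimidine there carries two methyl groups and the one on compound 2 carries none, and the core of compound 2 is not that of compound 1. A lower number for compound 4 than the limit of compound 2 is therefore expected, of modest size, with the chance that compound 4 too returns only a limit. The estimate for compound 4 in this assay is 60000 nM, within 20000 nM to 200000 nM, which means an expected step of an at least 1.6-fold lower number from compound 2 to compound 4 (0.22 log units; that floor lies within the scatter).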

Compound 4, half-maximal inhibitory concentration: > 100000 nM
Compound 4 gave a limit, no number; the forecaster's own chance of this, stated with the estimate: 40%; at least 1.6-fold (0.22 log units) between middle value and limit.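

In this assay, among the compounds shown here, compound 4 gives only a limit (> 100000 nM), and compound 2 also stands at a limit, so no step between the two can be read. The compounds shown leave open whether this exchange on the sulfonamide nitrogen changes the read-out on their shared core at all.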